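The source may hold more compounds than are shown below. What is called first, only, known or untested is meant among the compounds shown, and "the series" means these compounds.

Measured so far in a functional assay on Huh-7 cells (Homo sapiens) for inhibition, read by sulforhodamine B assay, with a stated time of 72 h; on this read-out higher numbers stand for weaker inhibition and lower numbers for stronger inhibition:
compound 1 `COc1ccc(C(=O)/C=C/c2cn(-c3ccccc3)nc2-c2ccsc2)cc1OC` gives 2900 nM
compound 2 `O=C(/C=C/c1cn(-c2ccccc2)nc1-c1cccnc1)c1ccccc1` gives 2300 nM
compound 3 `COc1ccc(C(=O)/C=C/c2cn(-c3ccccc3)nc2-c2cccnc2)c(OC)c1OC` gives 2300 nM

Compound 3 sits level with compound 2 at the digits recorded, the two of them at the lowest numbers of the three, and compound 1 stands within the scatter of both, so the three are not separated in this assay. Compound 4 `COc1ccc(C(=O)/C=C/c2cn(-c3ccccc3)nc2-c2cccnc2)cc1OC` differs from compound 3 by hydrogen in place of methoxy on an aromatic carbon. Going by the values given here, no pair of measured compounds isolates this change. Because compound 1 gives 2900 nM and compound 2 gives 2300 nM, both inside the scatter of compound 3, the expected step of a 1.1-fold higher number from compound 3 to compound 4 (0.04 log units; within the scatter) is none beyond the scatter in this assay. Compound 4 is expected to give 2500 nM, with a range of 1200 nM to 5200 nM.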

Compound 4, half-maximal inhibitory concentration: 3100 nM
Compound 4: middle estimate off by 1.2-fold (0.09 log units), on the low side, within the range that was stated.
By their numbers in this assay, from the lowest: compounds 2, 3, 1 and 4 (each within the scatter of the next).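

In this assay, hydrogen in place of methoxy on an aromatic carbon gives a 1.3-fold higher number from compound 3 to compound 4 (0.13 log units; within the scatter), so this position shows no effect beyond the scatter for this change. The two other single changes also stay within the scatter: 3,4-dimethoxyphenyl in place of phenyl on a carbonyl carbon gives a 1.3-fold higher number from compound 2 to compound 4 (0.13 log units; within the scatter), and pyridin-3-yl in place of thiophen-3-yl on an aromatic carbon gives a 1.1-fold higher number from compound 1 to compound 4 (0.03 log units; within the scatter). No supporting measurement accompanies these steps. From the compounds shown here alone, it remains open whether an amine or a carboxylic acid on this aromatic carbon would move the number beyond the scatter. Which part of the shared core the read-out depends on also remains open.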